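The source may hold more compounds than are shown below. What is called first, only, known or untested is meant among the compounds shown, and "the series" means these compounds.

The measured compounds, each tested in an assay on HEK293 cells for negative allosteric modulation of metabotropic glutamate receptor 5 (Homo sapiens), read by FLIPR, with a stated time of 1 h; a lower number here means a stronger inhibitor, a higher number a weaker inhibitor:

Compound 1 `C(#Cc1nc2c(s1)CN(C1CCCCC1)CC2)c1ccccc1` gives > 10000 nM in this assay; this is a limit of the assay, not a number.
Compound 2 `O=C(C1CC12CCC2)N1CCc2nc(C#Cc3ccccc3)sc2C1` gives > 10000 nM in this assay, again only a limit.
Compound 3 `O=C(C1CC(F)C1)N1CCc2nc(C#Cc3ccccc3)sc2C1` gives > 10000 nM in this assay, also only a limit.

Compound 3 therefore stands where every measured compound stands: the limit of > 10000 nM in this assay, at which 3 of the 3 values shown sit. For the measured compounds named here, because all three values are limits, the three comparisons between them, a step that the two limits leave unreadable from compound 1 to compound 2, a step that the two limits leave unreadable from compound 1 to compound 3 and a step that the two limits leave unreadable from compound 2 to compound 3, give no readable size, only that none of the changes on the amine nitrogen brought a compound inside the measurable range.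

Compound 4 `CC(C)S(=O)(=O)N1CCc2nc(C#Cc3ccccc3)sc2C1` differs from compound 3 in one place: isopropylsulfonyl in place of (3-fluorocyclobutyl)carbonyl on an amine nitrogen in a ring. Going by the values given here, no measured step touches a sulfonyl group, so nothing among the three compounds says whether this change moves the value in either direction beyond the scatter. The expectation for compound 4 is that it remains, like compound 3, most likely at the limit, with the step that the limit leaves unreadable from compound 3 to compound 4 estimated as essentially none. Compound 4 is expected at about 15000 nM, within a range from 3000 nM to 50000 nM.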

Compound 4, half-maximal inhibitory concentration: 11 nM
Beside the measured number, compound 4's estimate is 1400-fold (3.13 log units) above it, outside the stated range (below it).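

This result shows that the group on the amine nitrogen in a ring can decide whether these compounds register in this assay at all. Isopropylsulfonyl in place of (3-fluorocyclobutyl)carbonyl gives an at least 900-fold lower number from compound 3 to compound 4 (2.95 log units; beyond the scatter), and the same group gives an at least 900-fold lower number from compound 2 to compound 4 (2.95 log units; beyond the scatter) when it replaces the carbonyl group with two rings, and an at least 900-fold lower number from compound 1 to compound 4 (2.95 log units; beyond the scatter) when it replaces cyclohexyl. Two carbonyl-linked groups and a cyclohexyl therefore all fail at this place, while compound 4 alone comes inside the measurable range: the limit of > 10000 nM in this assay, at which 3 of the 4 values shown sit.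

The compounds shown leave open whether the sulfonyl group or its isopropyl part matters more, and an isobutyryl group at the same place would separate the two. They also leave open how a methylsulfonyl group or a longer chain on the sulfur would change the value.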